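The source may hold more compounds than are shown below. What is called first, only, known or untested is meant among the compounds shown, and "the series" means these compounds.

In a functional assay on NCI-H1975 cells (Homo sapiens) for antiproliferative activity, read by CCK-8 assay, with a stated time of 72 h (a higher number here means a weaker inhibitor of growth, a lower number a stronger inhibitor of growth), three compounds have been measured so far. Compound 1 (`CCC1C(=O)N(C)c2cnc(Nc3ccc(S(=O)(=O)NC)cc3)nc2N1c1ccn(C)n1`) gives 18800 nM, the highest of the three numbers. Compound 2 (`CC[C@@H]1C(=O)N(C)c2cnc(Nc3ccc(S(N)(=O)=O)cc3)nc2N1C1CCCC1`) gives 5290 nM and compound 3 (`CC[C@@H]1C(=O)N(C)c2cnc(-n3ccc4cc(C(=O)NC(C)C)ccc43)nc2N1C1CCCC1`) gives 1840 nM. Both lie beyond the scatter on the lower side of compound 1, but neither differs from it in one place only, so no measured single change is available as a guide.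

Compound 4 (`CCC1C(=O)N(C)c2cnc(Nc3ccc(S(=O)(=O)NCCCO)cc3)nc2N1c1ccn(C)n1`) differs from compound 1 in one place, on a saturated chain carbon bound to a sulfonamide nitrogen: 2-hydroxyethyl in place of hydrogen on a saturated chain carbon bound to a sulfonamide nitrogen. Cut one bond further out, the same difference reads methyl to 3-hydroxypropyl. Among the compounds with values here, with no measured precedent for this change, no step beyond the scatter is expected in this assay, with only a slight lean towards a lower number. The estimated value for compound 4 is 12000 nM, with an expected range of 4500 nM to 30000 nM. The expected change is a 1.6-fold lower number from compound 1 to compound 4 (0.19 log units; within the scatter).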

Compound 4, concentration for 50% growth inhibition: 25800 nM
Compound 4: the middle estimate sits 2.2-fold (0.33 log units) below what was measured; the range from low to high includes it.
By their numbers in this assay, from the lowest: compound 3; then compound 2; then compounds 1 and 4 (each within the scatter of the next).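

In this assay, going from methylsulfamoyl to (3-hydroxypropyl)sulfamoyl gives a 1.4-fold higher number from compound 1 to compound 4 (0.14 log units; within the scatter). Within the data shown here, this is the first single change that can be read, something the earlier compounds, none of which differed from another in one place, could not provide. It shows that at this place, on a saturated chain carbon bound to a sulfonamide nitrogen, 2-hydroxyethyl in place of hydrogen produces no step beyond the scatter. Nothing measured here bears on why this is so.

Going by these compounds, whether an amine or a carboxylic acid at the end of this chain, or a longer chain, would produce a step beyond the scatter remains open. On these data alone, it is also open whether the same change would give a similar result on the core of compound 2.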